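The compounds below may be only part of what the source reports. "The series", "measured", "known", "first", "only" and "open" are said of these compounds alone.

Measured compounds in a functional assay on DU-145 cells (Homo sapiens) for cytotoxicity, read by sulforhodamine B assay, with a stated time of 48 h; a lower number here means a stronger inhibitor of growth, a higher number a weaker inhibitor of growth:
Compound 1 `CN1CCN(c2nc(Nc3ccc(C#N)c(C(F)(F)F)c3)nc(Oc3ccnc4ccccc34)n2)CC1` gives 51200 nM.
Compound 2 `N#Cc1ccc(Nc2nc(Oc3ccnc4ccccc34)nc(N3CCN(c4ccccn4)CC3)n2)cc1C(F)(F)F` gives 85900 nM.
Compound 3 `N#Cc1ccc(Nc2nc(Oc3ccnc4ccccc34)nc(N3CCN(c4ncccn4)CC3)n2)cc1C(F)(F)F` gives 85200 nM.

Compound 3 stands close to both of the others on these numbers. The step from compound 2 to compound 3 is a 1.0-fold lower number from compound 2 to compound 3 (0.00 log units; within the scatter), and the step from compound 1 to compound 3 is a 1.7-fold higher number from compound 1 to compound 3 (0.22 log units; within the scatter), so all three numbers sit within the scatter of one another and none can be called stronger or weaker than the rest.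

The next step leads to compound 4 `N#Cc1ccc(Nc2nc(Oc3ccnc4ccccc34)nc(N3CCN(Cc4ccccc4)CC3)n2)cc1C(F)(F)F`. Its change is benzyl in place of pyrimidin-2-yl on an amine nitrogen in a ring. Within the data shown here, every measured step so far has touched the same ring nitrogen: the step from compound 1 to compound 2 is a 1.7-fold higher number from compound 1 to compound 2 (0.22 log units; within the scatter), and the two steps already named leave compound 3 with its neighbours. Three substitutions at this nitrogen, a methyl, a pyridin-2-yl and a pyrimidin-2-yl, have given numbers that do not separate in this assay. On that basis the benzyl group is expected to give no step beyond the scatter either, with no direction to it; the expected step from compound 3 to compound 4 is a 1.2-fold lower number from compound 3 to compound 4 (0.09 log units; within the scatter). Compound 4 is therefore estimated at 70000 nM, within a range from 30000 nM to 160000 nM.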

Compound 4, concentration for 50% growth inhibition: > 100000 nM
Compound 4: only a limit was reported; the forecaster's own chance of this, stated with the estimate: 15%; middle value at least 1.4-fold (0.15 log units) from the limit.
By their numbers in this assay, from the lowest: compounds 1, 3 and 2 (each within the scatter of the next). At a limit, above all of these: compound 4.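

In this assay compound 4 is reported only as a limit (> 100000 nM), not as a number. Among these compounds, it is the first compound here with a benzyl group on this ring nitrogen, the first whose ring holds carbon only and the first with a limit in place of a number, while the methyl, pyridin-2-yl and pyrimidin-2-yl compounds all gave numbers. The limit sets only floors for the steps (an at least 1.1-fold higher number from compound 3 to compound 4 (0.06 log units; that floor lies within the scatter); an at least 1.1-fold higher number from compound 2 to compound 4 (0.06 log units; that floor lies within the scatter); an at least 1.9-fold higher number from compound 1 to compound 4 (0.29 log units; that floor lies within the scatter)), and all three floors lie within the scatter, so the change to benzyl is not shown to weaken growth inhibition, though the real steps could be larger than these floors.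

As far as these compounds go, how far compound 4 truly lies from the other three therefore stays open, and with it whether a benzyl group at this nitrogen differs from the pyrimidin-2-yl group at all. Also open, from the compounds shown here alone, is what a benzoyl group, a longer chain such as phenylethyl, or a free amine hydrogen at this nitrogen would give in this assay on the same core.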